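A few compounds are considered here, and "the series" means these few. Any claim that something is new, unique, unknown or untested is made for them only; others in the source may bear on it.

Compound 3 `Cc1cc(-c2cccnc2)nnc1N1CCN(c2ncccn2)CC1` sits at the edge of what a functional assay on BV-2 cells (Mus musculus) for inhibition, read by ELISA, with a stated time of 16 h (a higher number here means a weaker inhibitor, a lower number a stronger inhibitor), can report: in this assay compound 3 gives > 100000 nM, which is a limit of the assay rather than a measured number. Compound 1 `Cc1cc(C(C)C)nnc1N1CCN(c2ncccn2)CC1` also returns only a limit, giving > 100000 nM in this assay. Among the measured compounds shown here, compound 2 `Cc1cc(-c2ccc(F)cc2)nnc1N1CCN(c2ncccn2)CC1` supplies the one measured number, with 76300 nM in this assay. Compound 4 `Cc1cc(-c2ccc3[nH]ccc3c2)nnc1N1CCN(c2ncccn2)CC1` differs from compound 3 by 1H-indol-5-yl in place of pyridin-3-yl on an aromatic carbon. The earlier swap at the same position, the step of an at least 1.3-fold higher number from compound 2 to compound 3 (0.11 log units; that floor lies within the scatter), bears on this, while the step that the two limits leave unreadable from compound 1 to compound 3 gives no size; the limit of > 100000 nM in this assay, at which 2 of the 3 values shown sit, shows how little the numbers resolve. A somewhat lower number is expected, a step of an at least 1.6-fold lower number from compound 3 to compound 4 (0.22 log units; that floor lies within the scatter). Compound 4 is therefore estimated at 60000 nM, between 15000 nM and 250000 nM.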

Compound 4, half-maximal inhibitory concentration: 85100 nM
Estimate against measurement, compound 4: 1.4-fold (0.15 log units) below; the measured number falls inside the stated range.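

In this assay, the 1H-indol-5-yl group gives this position its second measured number, and the larger two-ring group with its hydrogen-bond donor reads the same as 4-fluorophenyl: a 1.1-fold higher number from compound 2 to compound 4 (0.05 log units; within the scatter). Swapping one aromatic group for the other therefore moves nothing that can be told from scatter. Against the two limit compounds only floors exist, an at least 1.1-fold lower number from compound 3 to compound 4 (0.07 log units; that floor lies within the scatter) and an at least 1.1-fold lower number from compound 1 to compound 4 (0.07 log units; that floor lies within the scatter), so neither shows a real gain: the limit of > 100000 nM in this assay, at which 2 of the 4 values shown sit.

Open, from the compounds shown here alone, is whether an amine or a carboxylic acid at this position would bring the number clearly down. Also open, going by these compounds, is whether any position elsewhere on the shared core matters more.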